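Replacing a nitrophenyl with a chlorophenyl on the shared core

The source may hold more compounds than are shown below. What is called first, only, known or untested is meant among the compounds shown, and "the series" means these compounds.

Compound 2 `CCOC(=O)C1=C(C)NC(=O)NC1c1cn(C(=O)CNc2ccccc2[N+](=O)[O-])c2ccccc12` gives 1.48 in a physicochemical assay for lipophilicity (on this read-out higher numbers stand for higher lipophilicity and lower numbers for lower lipophilicity), the lowest of the three numbers measured. Compound 3 `CCOC(=O)C1=C(C)NC(=S)NC1c1cn(C(=O)CNc2cccc([N+](=O)[O-])c2)c2ccccc12` gives 2.88, and compound 1 `CCOC(=O)C1=C(C)NC(=S)NC1c1cn(C(=O)CNc2ccc([N+](=O)[O-])cc2C)c2ccccc12` gives 3.34; both carry a thiocarbonyl where compound 2 carries a carbonyl in the shared core, so their gap to compound 2 is not a single change. Among the compounds with values here, the one single-point step measured, a number 0.46 log units lower from compound 1 to compound 3 (beyond the scatter), swaps one substituted aryl group on the amine nitrogen for another and is modest.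

Compound 4 `CCOC(=O)C1=C(C)NC(=O)NC1c1cn(C(=O)CNc2ccc(Cl)cc2)c2ccccc12` differs from compound 2 by 4-chlorophenyl in place of 2-nitrophenyl on an amine nitrogen. Within the data shown here, no measured step exchanges a nitro-bearing aryl for a chloro-bearing one, so the step from compound 1 to compound 3 is only a loose guide to how much the aryl group can move this assay. Compound 4 is expected to rise, with a step of a number 0.82 log units higher from compound 2 to compound 4 (beyond the scatter) from compound 2. Compound 4 is therefore estimated at 2.3, within a range of 1.7 to 2.9.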

Compound 4, partition coefficient: 2.04
Beside the measured number, compound 4's estimate is 0.26 log units above it; low and high end bracket the measured number.
By their numbers in this assay, from the lowest: compound 2; then compound 4; then compound 3; then compound 1.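

In this assay, within the data shown here, the exchange of 2-nitrophenyl for 4-chlorophenyl on an amine nitrogen gives a number 0.56 log units higher from compound 2 to compound 4 (beyond the scatter) and is the first step measured with a carbonyl in the shared core. Among these compounds, the only earlier step, a number 0.46 log units lower from compound 1 to compound 3 (beyond the scatter) on the thiocarbonyl core, is also modest, so the aryl group at this position moves the number on both cores, although the two steps exchange different groups. Nothing at hand explains the size or direction of the new step.

From the compounds shown here alone, the new step changes both the substituent and its place on the phenyl ring, so the share of each remains open. Going by these compounds, it also remains open how an amine or a carboxylic acid on that ring would read, and whether a single exchange of carbonyl for thiocarbonyl moves the number on its own.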